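Amide-nitrogen substituent series against histone deacetylase 4

The compounds below may be only part of what the source reports. "The series", "measured", "known", "first", "only" and "open" are said of these compounds alone.

Measured so far:
compound 1 `O=C(COc1ccc2cc(/C=C3/SC(=O)NC3=O)ccc2c1)Nc1ccccn1`: 17000 nM
compound 2 `O=C(COc1ccc2cc(/C=C3/SC(=O)NC3=O)ccc2c1)Nc1cccc(F)n1`: 840 nM
compound 3 `Cc1cc(Br)ccc1NC(=O)COc1ccc2cc(/C=C3/SC(=O)NC3=O)ccc2c1`: 550 nM

In an assay on isolated protein for inhibition of histone deacetylase 4 (Homo sapiens), with a stated time of 1 h (a lower number here means a stronger inhibitor, a higher number a weaker inhibitor), compound 1 gives the highest of the three numbers; its nearest neighbour is compound 2, a 20-fold lower number from compound 1 to compound 2 (1.31 log units; beyond the scatter), and the furthest is compound 3, a 31-fold lower number from compound 1 to compound 3 (1.49 log units; beyond the scatter). Compound 2 and compound 3 lie within the scatter of each other, a 1.5-fold lower number from compound 2 to compound 3 (0.18 log units; within the scatter).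

Compound 4 `Cc1cccc2sc(NC(=O)COc3ccc4cc(/C=C5/SC(=O)NC5=O)ccc4c3)nc12` is not yet measured. It differs from compound 1 as follows: 4-methyl-1,3-benzothiazol-2-yl in place of pyridin-2-yl on an amide-type nitrogen

Going by the values given here, the step that bears most directly on this is the one from compound 1 to compound 3, also a replacement of the pyridin-2-yl group on an amide-type nitrogen, which was large. The change from compound 1 to compound 2 shows that altering this part of the molecule has, in both shown cases, brought a large drop in the number. For compound 4 a large step downward is therefore expected, a 24-fold lower number from compound 1 to compound 4 (1.39 log units; beyond the scatter). The value for compound 4 is estimated at 700 nM, within a range of 200 nM to 3000 nM.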

Compound 4, half-maximal inhibitory concentration: 1200 nM
The estimate for compound 4 lay 1.7-fold (0.23 log units) below the measured number; low and high end bracket the measured number.
By their numbers in this assay, from the lowest: compounds 3, 2 and 4 (each within the scatter of the next, the first and the last beyond it); then compound 1.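

The 4-methyl-1,3-benzothiazol-2-yl group also lowers the number relative to pyridin-2-yl (a 14-fold lower number from compound 1 to compound 4 (1.15 log units; beyond the scatter)), so the large drop extends to a five-membered aromatic ring fused to a carbon-only six-membered ring. It is modestly weaker than the 4-bromo-2-methylphenyl group (a 2.2-fold higher number from compound 3 to compound 4 (0.34 log units; beyond the scatter)) and not separated from 6-fluoropyridin-2-yl (a 1.4-fold higher number from compound 2 to compound 4 (0.15 log units; within the scatter)), leaving pyridin-2-yl alone apart from the other three. Nothing available explains these differences.

Open, from the compounds shown here alone, is what the methyl contributes, which the unsubstituted 1,3-benzothiazol-2-yl group would test. Also open, going by these compounds, is how an amine or carboxylic acid on this amide-nitrogen substituent would fare.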